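The source may report more compounds than this note shows. Statements on the series, on what has been measured and on what is new or still open speak of the compounds shown alone.

The measured compounds are:

compound 1, `O=C(O)CCc1ccc(OCc2nc(-c3ccccc3)no2)cc1`, with 1130 nM
compound 2, `CC(Oc1ccc(CCC(=O)O)cc1)c1nc(-c2ccccc2)no1`, with 2390 nM
compound 3, `O=C(O)CCc1ccc(OCc2nc(-c3cccc(C(F)(F)F)c3)no2)cc1`, with 1110 nM

In a functional assay on CHO cells for agonist activity at Free fatty acid receptor 1 (Homo sapiens), read by FLIPR and calcium flux, in the presence of a further agent that is not named here (a higher number here means that more compound is needed for the effect, a lower number that less compound is needed), compound 1 stands second highest of the three numbers. Its nearest neighbour is compound 3: the step from compound 1 to compound 3, trifluoromethyl in place of hydrogen on an aromatic carbon, gave a 1.0-fold lower number from compound 1 to compound 3 (0.01 log units; within the scatter). Its furthest neighbour is compound 2: the step from compound 1 to compound 2, methyl in place of hydrogen on the saturated chain carbon, gave a 2.1-fold higher number from compound 1 to compound 2 (0.33 log units; beyond the scatter).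

Compound 4, `O=C(O)CCc1ccc(OCc2nc(-c3ccc(C(F)(F)F)cc3)no2)cc1`, has not been measured. It differs from compound 1 in one place: trifluoromethyl in place of hydrogen on an aromatic carbon. The step from compound 1 to compound 3 bears directly on this, since the same group enters the same ring of the shared core, and that step stayed within the scatter. The step from compound 1 to compound 2 changes a different part of the molecule and says little here.

Compound 4 is therefore expected to sit close to compound 1, with a 1.1-fold lower number from compound 1 to compound 4 (0.05 log units; within the scatter) and no step beyond the scatter. The estimate for compound 4 is 1000 nM, within a range of 450 nM to 2300 nM.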

Compound 4, half-maximal effective concentration: 610 nM
For compound 4 the middle estimate is 1.6-fold (0.21 log units) above the measured one; low and high end bracket the measured number.
By their numbers in this assay, from the lowest: compounds 4, 3 and 1 (each within the scatter of the next); then compound 2.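

In this assay, placing trifluoromethyl para to a large group on the six-membered aromatic ring of carbon only gave a 1.9-fold lower number from compound 1 to compound 4 (0.27 log units; within the scatter), so this second placement of the group, like that in compound 3, produced no step beyond the scatter. Compound 3 gives 1110 nM and compound 4 gives 610 nM, two numbers within the scatter of each other, so these compounds do not separate the two placements of trifluoromethyl on this ring. No measurement here offers an explanation for these numbers.

The compounds shown leave open whether a different group at this place, such as a methoxy group, a chlorine atom or a nitrile, would move the number beyond the scatter, since trifluoromethyl is the only group tested on this ring. They also leave open whether the methyl on the chain carbon seen in compound 2 would give a similar step when combined with trifluoromethyl at this place, and what would follow if an amide took the place of the carboxylic acid.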